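The source may report more compounds than this note shows. Statements on the series, on what has been measured and on what is new or still open speak of the compounds shown alone.

Compound 1: `COc1ccc(-c2cc3ccc(OCCCCn4cc(CNC(=O)CCCCC5CCSS5)nn4)cc3oc2=O)cc1` — 48.6%
Compound 2: `CC(=O)c1cc2ccc(OCCCCCn3cc(CNC(=O)CCCCC4CCSS4)nn3)cc2oc1=O` — 20.8%

In a functional assay on PC-12 cells (Rattus norvegicus) for cytotoxicity, read by MTT assay, with stated times of 3 h and 2 h, tested at 10 uM (a lower number here means a weaker effect, a higher number a stronger effect of the compound at the concentration tested), compound 2 stands lowest of the two measured numbers, with compound 1 higher by an amount beyond the usual scatter. Compound 3 `COc1ccc(-c2cc3ccc(OCCCCCn4cc(CNC(=O)CCCCC5CCSS5)nn4)cc3oc2=O)cc1` is not yet measured. It differs from compound 2 in one place: 4-methoxyphenyl in place of acetyl on an aromatic carbon. Compound 1 also carries the 4-methoxyphenyl group, and in this assay compound 1 gives 48.6%, so a rise beyond the scatter is expected, a number 24.2 percentage points higher from compound 2 to compound 3 (beyond the scatter). Compound 3 is therefore estimated at 45%, with a likely range from 25% to 65%.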

Compound 3, a percentage reported as activity, at one concentration (the size of the read-out at that concentration, not a potency): 45.5%
Estimate against measurement, compound 3: 0.5 percentage points below; the range from low to high includes it.
By their numbers in this assay, from the lowest: compound 2; then compounds 3 and 1 (each within the scatter of the next).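

Compound 1 and compound 2 differ in two places, so their gap could not be tied to either one. In this assay the swap of acetyl for 4-methoxyphenyl on this aromatic carbon, two atoms from the ring oxygen, gives a number 24.7 percentage points higher from compound 2 to compound 3 (beyond the scatter) with the chain unchanged, so this position alone can move the read-out. Nothing measured here explains why. Still open, as far as these compounds go, is whether the methoxy or the aromatic ring carries the rise, which an unsubstituted phenyl would separate. An amine or a carboxylic acid at this carbon also remains untested in the compounds shown.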